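A few compounds are considered here, and "the series" means these few. Any claim that something is new, unique, unknown or untested is made for them only; others in the source may bear on it.

The measured compounds are compound 1 `O=C(N/N=C/c1ccc(F)cc1)Nc1ccc(Oc2ccnc3[nH]ccc23)c(F)c1` with 680 nM, compound 2 `N#Cc1ccc(/C=N/NC(=O)Nc2ccc(Oc3ccnc4[nH]ccc34)c(F)c2)cc1` with 1360 nM, and compound 3 `O=C(N/N=C/c1ccc(F)cc1Cl)Nc1ccc(Oc2ccnc3[nH]ccc23)c(F)c1` with 10 nM in a functional assay on A549 cells (Homo sapiens) for antiproliferative activity, read by MTT assay, with a stated time of 72 h; a higher number here means a weaker inhibitor, a lower number a stronger inhibitor.

Compound 1 stands second highest of the three numbers. Its nearest neighbour is compound 2, a 2.0-fold higher number from compound 1 to compound 2 (0.30 log units; within the scatter); its furthest is compound 3, a 68-fold lower number from compound 1 to compound 3 (1.83 log units; beyond the scatter).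

Compound 4 `O=C(N/N=C/c1ccc(O)c(Br)c1)Nc1ccc(Oc2ccnc3[nH]ccc23)c(F)c1` differs from compound 1 as follows: 3-bromo-4-hydroxyphenyl in place of 4-fluorophenyl on a carbon with a double bond to nitrogen. Within the data shown here, the step that bears on it is the one to compound 3, where a single added halogen on that ring gave a large gain. The step to compound 2 shows that swapping the fluoro for another group changed little. Among the measured compounds shown here, no measured step introduces a hydroxyl or a bromine, so the expectation is uncertain: a moderately lower number is expected, a 3.4-fold lower number from compound 1 to compound 4 (0.53 log units; beyond the scatter), giving an estimate for compound 4 of 200 nM with a range from 30 nM to 1400 nM.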

Compound 4, half-maximal inhibitory concentration: 9250 nM
Estimate against measurement, compound 4: 46-fold (1.67 log units) below; the whole stated range lies below it.
By their numbers in this assay, from the lowest: compound 3; then compounds 1 and 2 (each within the scatter of the next); then compound 4.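

In this assay, the place on the carbon with a double bond to nitrogen proves able to cost activity as well as gain it: 3-bromo-4-hydroxyphenyl gives a weaker result against each earlier group (in turn a 14-fold higher number from compound 1 to compound 4 (1.13 log units; beyond the scatter) and a 6.8-fold higher number from compound 2 to compound 4 (0.83 log units; beyond the scatter) and a 930-fold higher number from compound 3 to compound 4 (2.97 log units; beyond the scatter)). A halogen on this ring therefore does not bring a gain by itself, with compound 3 going one way and compound 4 the other. Nothing measured here accounts for the loss.

The compounds shown do not separate the bromine from the hydroxyl, as both enter together. Going by these compounds, whether a methoxy group or an amine in place of that hydroxyl would give the same result stays open.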